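Clearance notes: 1-ethyl-1H-pyrazol-4-yl to 3-carbamoylphenyl

This account rests on a few compounds, and the source may have more. Where it says the series, first, only, none or still open, it means among the compounds named here.

Measured in an ADME assay (liver) for metabolic stability, with Liver microsome (Homo sapiens) as the target, using microsomes and NADPH, with a stated time of 30 min, tested at 1 uM; a higher number here means faster removal of the compound, a lower number slower removal:
- compound 1 `Nc1ccc(S(=O)(=O)N2CCN(c3ncc(C(O)(C(F)(F)F)C(F)(F)F)cc3C#CC3CC3)CC2)cn1`: < 14 mL.min-1.g-1
- compound 2 `Cn1cc(-c2cc(C(O)(C(F)(F)F)C(F)(F)F)cnc2N2CCN(S(=O)(=O)c3ccc(N)nc3)CC2)cn1`: 19 mL.min-1.g-1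
- compound 3 `CCn1cc(-c2cc(C(O)(C(F)(F)F)C(F)(F)F)cnc2N2CCN(S(=O)(=O)c3ccc(N)nc3)CC2)cn1`: 20 mL.min-1.g-1

The entry for compound 1 is a limit of the assay and not a number: the limit of < 14 mL.min-1.g-1 in this assay, at which 1 of the 3 values shown sits. Compound 3 cannot be separated from its nearest neighbour: a 1.1-fold higher number from compound 2 to compound 3 (0.02 log units; within the scatter).

The next change is 3-carbamoylphenyl in place of 1-ethyl-1H-pyrazol-4-yl on an aromatic carbon, which gives compound 4 `NC(=O)c1cccc(-c2cc(C(O)(C(F)(F)F)C(F)(F)F)cnc2N2CCN(S(=O)(=O)c3ccc(N)nc3)CC2)c1`: 3-carbamoylphenyl in place of 1-ethyl-1H-pyrazol-4-yl on an aromatic carbon.

Two measured steps involve exchange on this aromatic carbon: an at least 1.3-fold higher number from compound 1 to compound 2 (0.13 log units; that floor lies within the scatter), and an at least 1.4-fold higher number from compound 1 to compound 3 (0.15 log units; that floor lies within the scatter). Neither floor lies beyond the scatter. For the measured compounds named here, no measured step brings in a 3-carbamoylphenyl group, so the range is kept wide.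

Starting from compound 3 at 20 mL.min-1.g-1, no step beyond the scatter is expected in this assay. The expected step is a 1.1-fold lower number from compound 3 to compound 4 (0.05 log units; within the scatter). Compound 4 is estimated at 18 mL.min-1.g-1, with an expected range of 11 mL.min-1.g-1 to 35 mL.min-1.g-1.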

Compound 4, intrinsic clearance in microsomes: 17 mL.min-1.g-1
Compound 4: middle estimate off by 1.1-fold (0.02 log units), on the high side; the measured number falls inside the stated range.
By their numbers in this assay, from the lowest: compounds 4, 2 and 3 (each within the scatter of the next). At a limit, below all of these: compound 1.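

In this assay, for the compounds shown here, this aromatic carbon carries a 3-carbamoylphenyl group, a six-membered aromatic ring of carbon only, with no separation from the five-membered pyrazole rings (a 1.2-fold lower number from compound 3 to compound 4 (0.07 log units; within the scatter); a 1.1-fold lower number from compound 2 to compound 4 (0.05 log units; within the scatter)), both steps within the scatter, whereas the earlier compounds compared only 1-methyl-1H-pyrazol-4-yl and 1-ethyl-1H-pyrazol-4-yl among ring groups. Set against 2-cyclopropylethynyl, the same group gives only a floor that also lies within the scatter (an at least 1.2-fold higher number from compound 1 to compound 4 (0.08 log units; that floor lies within the scatter)). That step stays a floor because compound 1 is a limit of the assay and not a number: the limit of < 14 mL.min-1.g-1 in this assay, at which 1 of the 4 values shown sits.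

As far as these compounds go, it remains open whether a carboxylic acid or a nitrile in place of the carbamoyl group would give a step beyond the scatter. From the compounds shown here alone, a saturated amine on this aromatic carbon is equally open.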